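A few compounds are considered here, and "the series" means these few. Any claim that something is new, unique, unknown or untested is made for them only; others in the source may bear on it.

Measured compounds:
compound 1 `Cc1ccc(CNC(=O)c2[nH]cnc2C(=O)Nc2ccc(Cl)c(Cl)c2)cc1` gives 15200 nM
compound 2 `COc1ccc(CNC(=O)c2[nH]cnc2C(=O)Nc2ccc(Cl)c(Cl)c2)cc1` gives 18300 nM
compound 3 `O=C(NCc1ccc(-c2ccccc2)cc1)c1nc[nH]c1C(=O)Nc1ccc(Cl)c(Cl)c1` gives 2900 nM

In a functional assay on HL-60 cells (Homo sapiens), with a stated time of 4 days (on this read-out lower numbers stand for stronger inhibition and higher numbers for weaker inhibition), compound 2 gives the highest number of the three measured. Its step from compound 1, a 1.2-fold higher number from compound 1 to compound 2 (0.08 log units; within the scatter), lies within the scatter, while compound 3 sits clearly apart with 2900 nM. Compound 4 `C[C@@H](NC(=O)c1[nH]cnc1C(=O)Nc1ccc(Cl)c(Cl)c1)C(=O)OC(C)(C)C` differs from compound 2 by 1-(tert-butoxycarbonyl)ethyl in place of 4-methoxybenzyl on an amide-type nitrogen. Within the data shown here, the only measured step exchanges one small group for another on the aromatic ring and is small; no measured step removes that ring altogether, so there is no direct guide to this change. With nothing to suggest a gain, compound 4 is expected at 25000 nM, with a range from 8000 nM to 70000 nM. This expectation corresponds to a step of a 1.4-fold higher number from compound 2 to compound 4 (0.14 log units; within the scatter).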

Compound 4, half-maximal inhibitory concentration: 2500 nM
For compound 4 the middle estimate is 10-fold (1.00 log units) above the measured one, outside the stated range (below it).
By their numbers in this assay, from the lowest: compounds 4 and 3 (each within the scatter of the next); then compounds 1 and 2 (each within the scatter of the next).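

In this assay, an aromatic ring on the amide-type nitrogen proves unnecessary: 1-(tert-butoxycarbonyl)ethyl, which has no ring, gives a 7.3-fold lower number from compound 2 to compound 4 (0.86 log units; beyond the scatter), and against the 4-methylbenzyl group it gives a 6.1-fold lower number from compound 1 to compound 4 (0.78 log units; beyond the scatter). Compound 4 and compound 3 lie within the scatter of each other, so two very different groups on this nitrogen give similar numbers. Nothing available explains this gain. Open, on these data alone, is whether a carboxylic acid in place of the tert-butyl ester would keep this number. As far as these compounds go, the opposite configuration at the stereocentre is equally open.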